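The compounds below may be only part of what the source reports. "The series", "measured", "known", "first", "only" and "open" are said of these compounds alone.

Compound 1 `C#Cc1cccc(Nc2ncnc3cc(OC)c(OCCCCC(=O)Nc4ccc(S(N)(=O)=O)cc4)cc23)c1`: in a functional assay on A-431 cells (Homo sapiens) for antiproliferative activity, read by MTT assay, with a stated time of 72 h (on this read-out higher numbers stand for weaker inhibition and lower numbers for stronger inhibition), compound 1 gives 17700 nM.
Compound 2 `NS(=O)(=O)c1ccc(NC(=S)Nc2ccc3ncnc(Nc4ccc(F)c(Cl)c4)c3c2)cc1`: in this assay compound 2 gives 37600 nM.
Compound 3 `C#Cc1cccc(Nc2ncnc3ccc(NC(=S)Nc4ccc(S(N)(=O)=O)cc4)cc23)c1`: in this assay compound 3 gives 15300 nM.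

Compound 3 stands at the lowest of the three numbers, although compound 1 lies within the scatter of it and only compound 2 stands beyond it. Compound 4 `NS(=O)(=O)c1ccc(NC(=S)Nc2ccc3ncnc(Nc4ccc(Cl)c(C(F)(F)F)c4)c3c2)cc1` differs from compound 3 in one place: 4-chloro-3-(trifluoromethyl)phenyl in place of 3-ethynylphenyl on a nitrogen on an aromatic ring. For the measured compounds named here, the one measured step that bears on this change is a 2.5-fold lower number from compound 2 to compound 3 (0.39 log units; beyond the scatter), where 3-chloro-4-fluorophenyl gave way to 3-ethynylphenyl and the number fell. Compound 4 moves the other way, from 3-ethynylphenyl to another chlorine-bearing phenyl, so a higher number than that of compound 3 is expected in this assay, of a size comparable to that measured step. The expected step is a 2.1-fold higher number from compound 3 to compound 4 (0.32 log units; beyond the scatter). Compound 4 is therefore estimated at 32000 nM in this assay, within a range from 12000 nM to 85000 nM. As 4-chloro-3-(trifluoromethyl)phenyl is not the same group as 3-chloro-4-fluorophenyl, the range is kept wide.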

Compound 4, half-maximal inhibitory concentration: 18200 nM
The estimate for compound 4 lay 1.8-fold (0.25 log units) above the measured number; the measured number falls inside the stated range.
By their numbers in this assay, from the lowest: compounds 3, 1 and 4 (each within the scatter of the next); then compound 2.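

In this assay, the place on the nitrogen on an aromatic ring now has a second group to set against 3-ethynylphenyl, and a 1.2-fold higher number from compound 3 to compound 4 (0.08 log units; within the scatter) leaves the two groups indistinguishable, even though 4-chloro-3-(trifluoromethyl)phenyl has more heavy atoms and includes chlorine. Chlorine on this phenyl therefore does not by itself go with the number of compound 2, since a 2.1-fold lower number from compound 2 to compound 4 (0.32 log units; beyond the scatter) separates two chlorine-bearing groups and lies beyond the scatter. No measurement shown here accounts for this difference between the two groups.

On these data alone, it remains open whether an amine or a carboxylic acid on this phenyl would move the number beyond the scatter of compound 3. Also open, as far as these compounds go, is whether 4-chloro-3-(trifluoromethyl)phenyl would give a similar number on the core of compound 1.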